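The compounds below may be only part of what the source reports. "The series", "measured", "known", "first", "only" and "open" are said of these compounds alone.

In a functional assay on U-937 cells (Homo sapiens) for cytotoxicity, read by MTT assay, with a stated time of 48 h (on this read-out higher numbers stand for weaker inhibition and lower numbers for stronger inhibition), compound 1 `NC(=O)CC[C@H](NS(=O)(=O)c1ccc([N+](=O)[O-])cc1)C(=O)O` reads > 500000 nM, and this value is a limit of the assay. Within the data shown here, compound 2 `CC(C)NC(=O)CC[C@H](NS(=O)(=O)c1ccc([N+](=O)[O-])cc1)C(=O)O` gives 95100 nM, and compound 3 `CCCCCNC(=O)CC[C@H](NS(=O)(=O)c1ccc([N+](=O)[O-])cc1)C(=O)O` gives 32100 nM, the lowest number so far. Adding a chain to the amide-type nitrogen gave an at least 5.2-fold lower number from compound 1 to compound 2 (0.72 log units; beyond the scatter) and an at least 15-fold lower number from compound 1 to compound 3 (1.19 log units; beyond the scatter), while lengthening it gave a 3.0-fold lower number from compound 2 to compound 3 (0.47 log units; beyond the scatter). Compound 4 `O=C(CC[C@H](NS(=O)(=O)c1ccc([N+](=O)[O-])cc1)C(=O)O)NCc1ccccc1` now carries phenyl in place of butyl on a saturated chain carbon bound to an amide-type nitrogen. Among the measured compounds shown here, no measured step brings in a ring, so the modest 3.0-fold lower number from compound 2 to compound 3 (0.47 log units; beyond the scatter) sets the scale, and at most a small rise in number is expected in this assay. The expected change is a 1.2-fold higher number from compound 3 to compound 4 (0.10 log units; within the scatter). For compound 4 the estimate is 40000 nM, with an expected range of 18000 nM to 90000 nM.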

Compound 4, half-maximal inhibitory concentration: 102000 nM
Compound 4: middle estimate off by 2.6-fold (0.41 log units), on the low side; measured number above the stated range.
By their numbers in this assay, from the lowest: compound 3; then compounds 2 and 4 (each within the scatter of the next). At a limit, above all of these: compound 1.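

Replacing butyl with phenyl on a saturated chain carbon bound to an amide-type nitrogen gives a 3.2-fold higher number from compound 3 to compound 4 (0.50 log units; beyond the scatter) here, so the larger group does not bring a lower number. Benzyl and isopropyl cannot be told apart, with a 1.1-fold higher number from compound 2 to compound 4 (0.03 log units; within the scatter) in this comparison. Benzyl on the amide nitrogen still gives an at least 4.9-fold lower number from compound 1 to compound 4 (0.69 log units; beyond the scatter) as its step, and that size is only a bound since compound 1 stands at a limit: the limit of > 500000 nM in this assay, at which 1 of the 4 values shown sits.

From the compounds shown here alone, whether a longer chain such as hexyl would lower the number further than pentyl remains open. So does the effect of a phenethyl group or an amine on this nitrogen.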